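The compounds below may be only part of what the source reports. "The series", "measured", "known", "first", "only" and "open" are said of these compounds alone.

In a physicochemical assay for lipophilicity, read by HPLC, measured as chromatographic lipophilicity, at pH 7.4 (a higher number here means a more lipophilic compound, a lower number a more polar compound), compound 1 `O=C(C1CCN(c2ncccn2)CC1)N1N=CC[C@H]1c1ccccc1` gives 4.7. Compound 3 `O=C(C1CCC1)N1N=CCC1c1ccccc1` gives 4.7, so the two read alike at the top of the three measured numbers. Compound 2 `CN1CCC(C2CC=NN2C(=O)C(C)(C)C)CC1` gives 1.4, so it stands well apart from both, with the lowest of the three measured numbers.

The compound now awaiting measurement is compound 4 `CC(=O)N1CCC(C(=O)N2N=CC[C@H]2c2ccccc2)CC1`. It keeps the rest of compound 1 but carries acetyl in place of pyrimidin-2-yl on an amine nitrogen in a ring, three ring bonds from the ring atom that bears a large group: acetyl in place of pyrimidin-2-yl on an amine nitrogen in a ring. The swap therefore takes away a six-membered aromatic ring with 2 hetero atoms and brings in a group with no ring and 1 double bond outside aromatic rings.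

For the measured compounds named here, no two measured compounds differ in one place, so the data offer no direct precedent for this swap, and the expectation rests on the structural change itself. A fall in this assay beyond the usual scatter is expected, of moderate size. With compound 2 at 1.4 as the lowest reading so far, the expectation stays well clear of that number. The expected change is a number 1.30 log units lower from compound 1 to compound 4 (beyond the scatter). Compound 4 is estimated at 3.4, with an expected range from 2.8 to 4.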

Compound 4, distribution coefficient: 2.5
Compound 4: middle estimate off by 0.90 log units, on the high side, outside the stated range (below it).
By their numbers in this assay, from the lowest: compound 2; then compound 4; then compounds 1 and 3 (each within the scatter of the next).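

For the compounds shown here, for the first time, a change in one place can be read: in this assay acetyl in place of pyrimidin-2-yl on an amine nitrogen in a ring gives a number 2.20 log units lower from compound 1 to compound 4 (beyond the scatter) and that is a large step. Going by these compounds alone, this position, three ring bonds from the ring atom that bears a large group, is therefore one where the choice of group moves the reading strongly, something the earlier compounds, which differ in more than one place, could not show. Nothing measured here accounts for the size of this step.

Within the data shown here, the swap changes several counted features at once, removing a six-membered aromatic ring with 2 hetero atoms and bringing in a smaller group with no ring and a double bond outside aromatic rings, so the single step cannot show which of these features goes with the lower reading. Going by these compounds, whether the reading follows the aromatic ring, the carbonyl of the acetyl or simply the size of the group remains open, and phenyl, benzoyl or a plain methyl on the same nitrogen would help to separate these possibilities.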